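The compounds below may be only part of what the source reports. "The series", "measured", "known", "first", "only" and "open" are said of these compounds alone.

Compound 1 `COc1ccc(C(=O)NNC(=S)Nc2csc(-c3ccccc3)c2)cc1` and compound 2 `O=C(NNC(=S)Nc1csc(-c2ccccc2)c1)c1ccc(O)cc1` share one core, while compound 3 `COc1ccc(-c2nnc(Nc3csc(-c4ccccc4)c3)s2)cc1` and the not yet measured compound 4 `Oc1ccc(-c2nnc(Nc3csc(-c4ccccc4)c3)s2)cc1` share another; the difference between the two cores is not broken down here. In a functional assay on SK-MEL-28 cells (Homo sapiens) for inhibition, read by colorimetric assay and MTT assay, with a stated time of 72 h (on this read-out lower numbers stand for stronger inhibition and higher numbers for weaker inhibition), compound 1 gives 30000 nM, and compound 2 gives 71000 nM. The change from compound 1 to compound 2 is hydrogen in place of methyl on an oxygen on an aromatic ring, and it brought a 2.4-fold higher number from compound 1 to compound 2 (0.37 log units; beyond the scatter). For compound 3 only a limit is known in this assay, namely > 100000 nM, which is the limit of the assay and not a number, the one set out in the limit of > 100000 nM in this assay, at which 1 of the 3 values shown sits. Compound 4 carries the same kind of change on the second core, (hydrogen in place of methyl on an oxygen on an aromatic ring), at a place described in the same words. Compound 3 already sits at the limit, and the earlier step of a 2.4-fold higher number from compound 1 to compound 2 (0.37 log units; beyond the scatter) pointed toward weaker inhibition. Compound 4 is therefore expected to remain at the limit, with a step estimated at a step that the limit leaves unreadable from compound 3 to compound 4. Compound 4 is estimated at 200000 nM, between 100000 nM and 500000 nM.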

Compound 4, half-maximal inhibitory concentration: 57000 nM
Compound 4: the middle estimate sits 3.5-fold (0.55 log units) above what was measured; measured number outside the range, below it.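

In this assay the change from methoxy to hydroxy brought an at least 1.7-fold lower number from compound 3 to compound 4 (0.24 log units; that floor lies within the scatter), so the change did not carry over from one core to the other with the same direction or size: the same change on two cores in this assay, a 2.4-fold higher number (0.37 log units; beyond the scatter) from compound 1 to compound 2 and an at least 1.7-fold lower number (0.24 log units; that floor lies within the scatter) from compound 3 to compound 4, at least 4.1-fold (0.61 log units) apart, beyond the scatter of two such steps

For compound 3 the value > 100000 nM is a limit of the assay and not a number, and the step built on it is only a floor: the limit of > 100000 nM in this assay, at which 1 of the 4 values shown sits.

These two pairs show that the result of this change on one core could not be read across to the other core in this assay, but they do not show the reason, and they set no rule for any further core.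

The compounds shown leave open whether an amine or a carboxylic acid in place of the methoxy group, or a longer chain on that oxygen, would follow the step seen on the core of compound 1 or the one seen on the core of compound 3. They also leave open the true size of the step on the core of compound 3, for which only a floor is known.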